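The compounds below may be only part of what the source reports. "The series", "measured", "known", "first", "only" and "open" are said of these compounds alone.

Working notes on the series. Compound 1 `Cc1cnc(-c2ccccc2C(C)C)nc1NCc1ccc(-c2cccnc2)cc1` gives 70 nM in an assay on a protein complex for inhibition of ubiquitin carboxyl-terminal hydrolase 1/WD repeat-containing protein 48 (Homo sapiens), read by fluorescence; a lower number here means a stronger inhibitor, a higher number a weaker inhibitor. Compound 2 `Cc1nc(-c2ccccc2C(C)C)nc(NCc2ccc(-c3cccnc3)cc2)c1C` differs from compound 1 by methyl in place of hydrogen on an aromatic carbon; in this assay compound 2 gives 120 nM, the step being a 1.7-fold higher number from compound 1 to compound 2 (0.23 log units; within the scatter). Compound 3 `Cc1cnc(-c2ccccc2C(C)C)nc1NCC1CCN(c2cccnc2)CC1` has a different core from compound 1, and the difference between the two cores is not broken down here. In this assay compound 3 gives 80 nM. Compound 4 `Cc1ccc(N2CCC(CNc3nc(-c4ccccc4C(C)C)ncc3C)CC2)cn1` is not yet measured; it differs from compound 3 by methyl in place of hydrogen on an aromatic carbon. This is the same kind of change as that from compound 1 to compound 2, but the place differs: there the methyl sits on a six-membered aromatic ring with 2 nitrogen, ortho to a methyl group and meta to a 2-isopropylphenyl group, opposite the ring nitrogen; here it sits on a six-membered aromatic ring with 1 nitrogen, next to the ring nitrogen and para to a large group. Going by the values given here, the step expected in this assay is a 1.4-fold higher number from compound 3 to compound 4 (0.14 log units; within the scatter), since in the one precedent a 1.7-fold higher number from compound 1 to compound 2 (0.23 log units; within the scatter) stayed within the scatter. For compound 4 the estimate in this assay is 110 nM, expected to fall between 50 nM and 250 nM.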

Compound 4, half-maximal inhibitory concentration: 90 nM
Compound 4: middle estimate off by 1.2-fold (0.09 log units), on the high side; low and high end bracket the measured number.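

In this assay, the new step reads a 1.1-fold higher number from compound 3 to compound 4 (0.05 log units; within the scatter), with pyridin-3-yl becoming 6-methylpyridin-3-yl. Set beside the earlier step, the two cores give no measurable difference: the same change on two cores in this assay, a 1.7-fold higher number (0.23 log units; within the scatter) from compound 1 to compound 2 and a 1.1-fold higher number (0.05 log units; within the scatter) from compound 3 to compound 4, 1.5-fold (0.18 log units) apart, within the scatter of two such steps. So in both pairs, methyl in place of hydrogen on an aromatic carbon leaves the number within the scatter, but two pairs do not establish a rule for the series, and the methyl sits on a different ring in each pair, so the effect of the core cannot be separated from that of the place.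

As far as these compounds go, it remains open whether 6-methylpyridin-3-yl in place of pyridin-3-yl on the core of compound 1 gives a step like the one seen on the core of compound 3, which would compare the same place on two cores. From the compounds shown here alone, it is also open whether an ethyl, a methoxy or an amine at the place taken by the methyl in compound 4 would stay within the scatter of compound 3.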